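This account rests on a few compounds, and the source may have more. Where it says the series, first, only, none or still open, it means among the compounds named here.

Compound 1 `c1ccc(COc2cccc(-c3cn([C@@H]4CN5CCC4CC5)nn3)c2)cc1`: 6.67 nM
Compound 2 `c1ccc(COc2cccc(-c3cn(C4CN5CCC4CC5)nn3)c2)cc1`: 7.57 nM
Compound 3 `c1ccc(COc2cccc(-c3cn([C@H]4CN5CCC4CC5)nn3)c2)cc1`: 631 nM

These numbers come from an assay on HEK293 cells for displacement of a labelled ligand from Neuronal acetylcholine receptor; alpha3/beta4 (Homo sapiens), read by scintillation counting, with a stated time of 120 min; a lower number here means a stronger inhibitor, a higher number a weaker inhibitor. Compound 2 stands between the other two: its nearest neighbour is compound 1, with a 1.1-fold higher number from compound 1 to compound 2 (0.05 log units; within the scatter), and its furthest is compound 3, with an 83-fold higher number from compound 2 to compound 3 (1.92 log units; beyond the scatter). Compound 4 `FCCCOc1cccc(-c2cn(C3CN4CCC3CC4)nn2)c1` differs from compound 2 at a single place: 2-fluoroethyl in place of phenyl on a saturated chain carbon bound to an oxygen on an aromatic ring. Within the data shown here, none of the measured steps bears on this change; each of them, including a 95-fold higher number from compound 1 to compound 3 (1.98 log units; beyond the scatter), alters only the drawn configuration at the saturated ring carbon and leaves the benzyloxy group untouched. The expectation for compound 4 therefore rests on the value of compound 2 alone, and a moderate rise in the number is estimated, a 4.0-fold higher number from compound 2 to compound 4 (0.60 log units; beyond the scatter). Compound 4 is thus expected to give 30 nM, within a range from 8 nM to 150 nM.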

Compound 4, inhibition constant: 44.4 nM
Compound 4: middle estimate off by 1.5-fold (0.17 log units), on the low side; low and high end bracket the measured number.
By their numbers in this assay, from the lowest: compounds 1 and 2 (each within the scatter of the next); then compound 4; then compound 3.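

Among these compounds, exchanging the benzyloxy group for 3-fluoropropoxy gives a 5.9-fold higher number from compound 2 to compound 4 (0.77 log units; beyond the scatter) and so shows that this position, untouched in the earlier compounds, does move the number. The loss is modest in this pair, so the phenyl ring is not essential for displacing the labelled ligand. The available evidence concerns only drawn configuration and does not explain this change.

The compounds shown do not separate losing the phenyl ring from adding fluorine, a question a plain propoxy group could address. Also open, going by these compounds, is how the two drawn configurations of compound 4 would compare.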